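The source may report more compounds than this note shows. Statements on the series, on what has been measured and on what is new or still open speak of the compounds shown alone.

Measured so far:
compound 1 `O=C1C(Nc2ccccc2)=CC(=O)c2c1nc1n2[C@H]2OC[C@@H](O)[C@H]2OC1` — > 8000 nM
compound 2 `CCCN(CCC)C1=CC(=O)c2nc3n(c2C1=O)[C@H]1OC[C@@H](O)[C@H]1OC3` — > 16000 nM

Measured in a functional assay on HeLa cells (Homo sapiens) for inhibition, read by sulforhodamine B assay (on this read-out higher numbers stand for weaker inhibition and lower numbers for stronger inhibition), compound 1 gives > 8000 nM, which is a limit of the assay and not a number. Compound 2 gives > 16000 nM, likewise a limit. Both values shown are limits, so compound 1 cannot be ordered against compound 2. Compound 3 `CCOc1ccccc1NC1=CC(=O)c2c(nc3n2[C@H]2OC[C@@H](O)[C@H]2OC3)C1=O` differs from compound 1 in one place: ethoxy in place of hydrogen on an aromatic carbon. Among the compounds with values here, no measured step bears on this change, so compound 3 is expected to remain near the limit, with the step that the limit leaves unreadable from compound 1 to compound 3 estimated as none beyond the scatter. Compound 3 is expected at 10000 nM, within 3000 nM to 40000 nM.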

Compound 3, half-maximal inhibitory concentration: 8300 nM
Beside the measured number, compound 3's estimate is 1.2-fold (0.08 log units) above it, within the range that was stated.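

No step can be read from compound 1 to compound 3. Compound 1 gives > 8000 nM, which is a limit and not a number. The compounds shown leave open whether ethoxy in place of hydrogen changes inhibition at all.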